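Biphenyl diol series: aromatic substitution and cytotoxicity

The source may report more compounds than this note shows. Statements on the series, on what has been measured and on what is new or still open speak of the compounds shown alone.

Measured so far:
- compound 1, `OCCCCCC(O)c1ccc(-c2ccccc2)cc1`: 22000 nM
- compound 2, `Cc1ccccc1-c1ccc(C(O)CCCCCO)cc1`: 24000 nM
- compound 3, `Cc1ccc(-c2ccc(C(O)CCCCCO)cc2)cc1`: 22000 nM

In a functional assay on J774 cells (Mus musculus) for cytotoxicity, read by resazurin assay (a higher number here means a weaker inhibitor, a lower number a stronger inhibitor), compound 3 gives 22000 nM, level with compound 1 and, together with it, the lowest of the three numbers; all three values sit within the scatter of one another. The two methyl steps, a 1.1-fold higher number from compound 1 to compound 2 (0.04 log units; within the scatter) and no change at the digits printed from compound 1 to compound 3 (within the scatter), and the regioisomer step a 1.1-fold lower number from compound 2 to compound 3 (0.04 log units; within the scatter), all fall within the scatter, so the outer ring has so far shown no measurable influence. Compound 4, `OCCCCCC(O)c1ccc(-c2ccc(Cl)cc2)cc1`, differs from compound 3 by chloro in place of methyl on an aromatic carbon. Within the data shown here, no measured step swaps methyl for chloro, but the substituent changes seen so far bear on it and were all flat. The expectation is therefore no step beyond the scatter, no change at the digits printed from compound 3 to compound 4 (within the scatter), with compound 4 estimated at 22000 nM (range 12000 nM to 40000 nM).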

Compound 4, half-maximal inhibitory concentration: 17000 nM
For compound 4 the middle estimate is 1.3-fold (0.11 log units) above the measured one, within the range that was stated.
By their numbers in this assay, from the lowest: compounds 4, 1, 3 and 2 (each within the scatter of the next).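

In this assay, chloro on an aromatic carbon para to a large group stays within the scatter of both methyl and hydrogen at that place: a 1.3-fold lower number from compound 3 to compound 4 (0.11 log units; within the scatter) and a 1.3-fold lower number from compound 1 to compound 4 (0.11 log units; within the scatter). The change from 2-methylphenyl to 4-chlorophenyl is also within the scatter, a 1.4-fold lower number from compound 2 to compound 4 (0.15 log units; within the scatter), so a halogen now joins the flat substituent changes in this series. No available evidence bears on this result.

On these data alone, whether any group at this position can shift the number beyond the scatter remains open, and an amine or a carboxylic acid there would test it. As far as these compounds go, the effect of a longer chain on the shared core also remains open.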